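Removing one methoxy from the aryl ring of compound 2

A few compounds are considered here, and "the series" means these few. Any claim that something is new, unique, unknown or untested is made for them only; others in the source may bear on it.

Measured so far in a functional assay on UO-31 cells (Homo sapiens) for inhibition, read by sulforhodamine B assay, with a stated time of 48 h; on this read-out lower numbers stand for stronger inhibition of growth and higher numbers for weaker inhibition of growth:
- compound 1 `COc1ccc(-c2cc(/C=C/C(=O)c3ccc(N)cc3)[nH]n2)cc1`: 1180 nM
- compound 2 `COc1cc(-c2cc(/C=C/C(=O)c3ccc(N)cc3)[nH]n2)cc(OC)c1OC`: 1360 nM
- compound 3 `COc1ccc(C(=O)/C=C/c2cc(-c3cc(OC)c(OC)c(OC)c3)n[nH]2)cc1OC`: 1280 nM

Compound 2 gives the highest of the three numbers, but its separation from compound 3 is a 1.1-fold lower number from compound 2 to compound 3 (0.03 log units; within the scatter), within the scatter, and its separation from compound 1 is also within the scatter; the three values are indistinguishable on this read-out. Going by the values given here, the one step that differs in a single place, from compound 2 to compound 3, exchanges the group on the carbonyl carbon and produces no change beyond the scatter.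

Compound 4 `COc1ccc(-c2cc(/C=C/C(=O)c3ccc(N)cc3)[nH]n2)cc1OC` is not yet measured. Relative to compound 2 the change is hydrogen in place of methoxy on an aromatic carbon of the aryl ring attached to the shared core. Among the compounds with values here, no measured step touches this ring at all; compound 1 differs from compound 2 in more than one place and its value sits within the scatter of compound 2, which is all that can be said of that pair. Within the data shown here, the only single-place step, from compound 2 to compound 3, was within the scatter, and it concerns a different position. On this basis the expected step from compound 2 to compound 4 is a 1.0-fold lower number from compound 2 to compound 4 (0.02 log units; within the scatter), none beyond the scatter. For compound 4 the estimated value in this assay is 1300 nM, with a range from 650 nM to 2600 nM.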

Compound 4, concentration for 50% growth inhibition: 3030 nM
Compound 4: middle estimate off by 2.3-fold (0.37 log units), on the low side; the whole stated range lies below it.
By their numbers in this assay, from the lowest: compounds 1, 3 and 2 (each within the scatter of the next); then compound 4.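

Going by these compounds alone, the aryl ring attached to the shared core now gives the first steps that lie beyond the scatter: in this assay, hydrogen in place of methoxy on an aromatic carbon gives a 2.2-fold higher number from compound 2 to compound 4 (0.35 log units; beyond the scatter), and methoxy in place of hydrogen on an aromatic carbon gives a 2.6-fold higher number from compound 1 to compound 4 (0.41 log units; beyond the scatter), so both single-place changes into compound 4 raise the number. Exchanging methoxy and hydrogen on this ring therefore does not move the read-out in one direction, and across these three compounds the number does not simply follow the count of methoxy groups, with the effect of a methoxy depending on which aromatic carbon carries it. Nothing available explains why this ring responds in this way.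

The compounds shown leave open whether a hydroxyl, a fluorine or an amine on the carbon that differs between compound 2 and compound 4 would track hydrogen or methoxy. They also leave open whether the same steps on this ring would hold with 3,4-dimethoxyphenyl on the carbonyl carbon, the group carried by compound 3, rather than the 4-aminophenyl of compound 1, compound 2 and compound 4.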